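Methoxy for Chloro on the Core of Compound 1

The compounds below may be only part of what the source reports. "The series", "measured", "known", "first", "only" and "open" are said of these compounds alone.

Compound 1 `COc1cc2c(/C=C3/C(=O)Nc4ccc(Cl)cc43)c(Cl)n(Cc3cc(OC)c(OC)c(OC)c3)c2cc1C` is the point of reference here. Among the measured compounds shown here, in a functional assay on cells (Leukemia cell, Homo sapiens) for cytotoxicity, with a stated time of 48 h (a higher number here means a weaker inhibitor of growth, a lower number a stronger inhibitor of growth), compound 1 gives 4790 nM, the second highest of the three numbers known so far. Compound 2 `COc1cc2c(/C=C3/C(=O)Nc4cccc(Cl)c43)c(Cl)n(Cc3cc(OC)c(OC)c(OC)c3)c2cc1C`, which differs from it in one place, gives 14100 nM in this assay; the step of a 2.9-fold higher number from compound 1 to compound 2 (0.47 log units; beyond the scatter) lies beyond the scatter. Compound 3 `COc1c(/C=C2/C(=O)Nc3ccccc32)c2ccccc2n1-c1ccccc1`, built on a different core, gives 2630 nM in this assay, a number within the scatter of compound 1, so no order can be read between those two.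

Compound 4 `COc1ccc2c(c1)/C(=C\c1c(Cl)n(Cc3cc(OC)c(OC)c(OC)c3)c3cc(C)c(OC)cc13)C(=O)N2` is not yet measured. It differs from compound 1 by methoxy in place of chloro on an aromatic carbon. For the measured compounds named here, of the measured steps, only the one from compound 1 to compound 2 alters the same part of the core, and it exchanges one group for another of the same composition rather than swapping chloro for methoxy; it shows only that changes in that region can move the number beyond the scatter. Going by the values given here, no measured pair replaces chloro with methoxy anywhere. The expectation for compound 4 in this assay is therefore a step of a 1.1-fold lower number from compound 1 to compound 4 (0.03 log units; within the scatter), with no fixed direction and likely within the scatter. The estimate for compound 4 is 4500 nM, expected to fall between 1500 nM and 13000 nM.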

Compound 4, concentration for total growth inhibition: 77600 nM
Compound 4: middle estimate off by 17-fold (1.24 log units), on the low side, outside the stated range (above it).
By their numbers in this assay, from the lowest: compounds 3 and 1 (each within the scatter of the next); then compound 2; then compound 4.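

In this assay, methoxy in place of chloro on this aromatic carbon, meta to a fused ring and para to a fused ring, gives a 16-fold higher number from compound 1 to compound 4 (1.21 log units; beyond the scatter) and so marks a large loss of growth inhibition from a single exchange of groups. The earlier compounds shown here offered only a 2.9-fold higher number from compound 1 to compound 2 (0.47 log units; beyond the scatter) as a guide to this part of the core, a modest step that exchanged one group for another of the same composition, whereas the new step shows that the identity of the group entering here can move the number much further. Nothing available bears on why this exchange costs so much, so the size of the step stands as an observation without an explanation.

The compounds shown leave open whether the loss is specific to methoxy or would also appear with fluoro, methyl, hydroxyl or an amine on this carbon, and whether a longer chain such as ethoxy would go further in the same direction. They also leave open whether the same exchange would have a step of similar size on the different core of compound 3.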